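The source may hold more compounds than are shown below. What is called first, only, known or untested is meant among the compounds shown, and "the series" means these compounds.

Compounds measured in a functional assay on DU-145 cells (Homo sapiens) for inhibition, read by trypan blue exclusion, with a stated time of 72 h; a lower number here means a stronger inhibitor, a higher number a weaker inhibitor:
- Compound 1 `Cn1c(=O)c(S(=O)(=O)Cc2ccc(F)cc2)cc2cnc(Nc3ccc4[nH]ccc4c3)nc21`: 30000 nM
- Compound 2 `Cn1c(=O)c(S(=O)(=O)c2ccc(O)cc2)cc2cnc(Nc3ccc4[nH]ccc4c3)nc21`: 250 nM
- Compound 3 `Cn1c(=O)c(S(=O)(=O)c2ccc(N)cc2F)cc2cnc(Nc3ccc4[nH]ccc4c3)nc21`: 8000 nM

Of these three, compound 1 gives the highest number and compound 2 the lowest, with compound 3 between them at 8000 nM. Compound 4 `Cn1c(=O)c(S(=O)(=O)c2ccc([N+](=O)[O-])cc2F)cc2cnc(Nc3ccc4[nH]ccc4c3)nc21` differs from compound 3 by a single change, nitro in place of amino on an aromatic carbon.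

Going by the values given here, no measured step makes this exchange directly. The nearest evidence comes from changes of the whole group on the sulfonyl sulfur: a 120-fold lower number from compound 1 to compound 2 (2.08 log units; beyond the scatter), a 3.8-fold lower number from compound 1 to compound 3 (0.57 log units; beyond the scatter) and a 32-fold higher number from compound 2 to compound 3 (1.51 log units; beyond the scatter). These show that the number can move widely with this group, but none isolates the amino group. Compound 1, which carries neither amino nor hydroxy there, has the highest number at 30000 nM, and compound 4 also lacks both. Three compounds are thin support, so only a small rise in this assay, around the size of the usual scatter, is expected. The estimated change is a 1.9-fold higher number from compound 3 to compound 4 (0.27 log units; within the scatter). The estimate for compound 4 is 15000 nM, with an expected range of 4000 nM to 40000 nM.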

Compound 4, half-maximal inhibitory concentration: 400 nM
The estimate for compound 4 lay 38-fold (1.57 log units) above the measured number, outside the stated range (below it).
By their numbers in this assay, from the lowest: compounds 2 and 4 (each within the scatter of the next); then compound 3; then compound 1.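

In this assay, going by these compounds alone, the exchange of amino for nitro, on the aromatic carbon para to a large group, gives a 20-fold lower number from compound 3 to compound 4 (1.30 log units; beyond the scatter) and shows that this one place can carry much of the spread seen among the earlier compounds. The change of 4-hydroxyphenyl to 2-fluoro-4-nitrophenyl gives a 1.6-fold higher number from compound 2 to compound 4 (0.20 log units; within the scatter) and so a low number here does not require a hydroxy or amino group on the aromatic ring. The change of 4-fluorobenzyl to 2-fluoro-4-nitrophenyl gives a 75-fold lower number from compound 1 to compound 4 (1.88 log units; beyond the scatter) and so the lack of those two groups does not by itself account for the high number of compound 1.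

As far as these compounds go, whether a nitrile or a carboxylic acid on this carbon would match nitro, and whether nitro needs the fluoro group, stays open. No measurement available here explains why nitro and amino differ so much.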